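Adding a Carboxy Group to an Amide Kinase Inhibitor

The source may report more compounds than this note shows. Statements on the series, on what has been measured and on what is new or still open speak of the compounds shown alone.

Three compounds were measured in an assay on isolated protein for inhibition of Rho-associated protein kinase 1 (Homo sapiens), read by scintillation counting, radiometric assay and 33P incorporation, with a stated time of 40 min, in the presence of a further agent that is not named here; on this read-out higher numbers stand for weaker inhibition and lower numbers for stronger inhibition. Compound 1 `CN(C)c1ccc(C(=O)Nc2cccc(NC(=O)COc3ccc4c(c3)NC(=O)CC4)c2)cc1` reaches only a limit of this assay, > 10000 nM. Compound 2 `O=C(COc1ccc2c(=O)ccoc2c1)Nc1cccc(NC(=O)c2ccccc2)c1` gives 120 nM in this assay, the lowest of the two actual numbers shown, while compound 3 `O=C(COc1ccc2c(=O)ccoc2c1)Nc1cccc(NS(=O)(=O)c2ccc(OC(F)(F)F)cc2)c1` gives 6440 nM, a gap beyond the usual scatter of repeated measurements. Compound 4 `O=C(COc1ccc2c(=O)ccoc2c1)Nc1cccc(NC(=O)c2ccc(C(=O)O)cc2)c1` has not yet been measured. It differs from compound 2 in one place: carboxy in place of hydrogen on an aromatic carbon. No measured pair differs in just one place, so the size of such a step cannot be read off from the compounds shown. With everything else in the molecule left as in compound 2, the expected step is of modest size, a 2.1-fold higher number from compound 2 to compound 4 (0.32 log units; beyond the scatter), towards a somewhat higher number, though it could well fall within the scatter. Compound 4 is therefore expected to give about 250 nM in this assay, with a likely range from 60 nM to 1500 nM.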

Compound 4, half-maximal inhibitory concentration: 6890 nM
Beside the measured number, compound 4's estimate is 28-fold (1.44 log units) below it; measured number above the stated range.
By their numbers in this assay, from the lowest: compound 2; then compounds 3 and 4 (each within the scatter of the next). At a limit, above all of these: compound 1.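

Carboxy in place of hydrogen on the aromatic ring of the benzoyl group, para to a large group, brings a 57-fold higher number from compound 2 to compound 4 (1.76 log units; beyond the scatter) in this assay. This single-place step shows that this position does not accept every addition: an uncharged group of only 3 heavy atoms is enough to lose most of the inhibition seen with compound 2. Compound 4 still gives a real number, and only compound 1 stands at a limit: the limit of > 10000 nM in this assay, at which 1 of the 4 values shown sits.

On these data alone, whether the loss belongs to the carboxy group itself or would follow any group at this place stays open; a methyl ester, a primary amide, a methyl group or a fluorine atom there would help to separate the two. The compounds shown also cannot say why the number rises so far.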